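Swapping the aryl group on the piperazine of a saccharin-chain series

The compounds below may be only part of what the source reports. "The series", "measured", "known", "first", "only" and "open" are said of these compounds alone.

Measured in an ADME assay on HEK293 cells for displacement of a labelled ligand from 5-hydroxytryptamine receptor 6 (Homo sapiens), read by radioligand binding, with a stated time of 1 h; on this read-out lower numbers stand for stronger inhibition and higher numbers for weaker inhibition:
compound 1 `O=C1c2ccccc2S(=O)(=O)N1CCCCCCN1CCN(c2cccc(Cl)c2)CC1` gives 372 nM
compound 2 `O=C1c2ccccc2S(=O)(=O)N1CCCCCCN1CCN(c2ccc(Cl)c(Cl)c2)CC1` gives 132 nM

Compound 2 has the lower of the two numbers; its nearest neighbour is compound 1, and the step of a 2.8-fold lower number from compound 1 to compound 2 (0.45 log units; beyond the scatter) came from a chloro in place of hydrogen on an aromatic carbon. Compound 3 `COc1cccc(N2CCN(CCCCCCN3C(=O)c4ccccc4S3(=O)=O)CC2)c1` carries instead (3-methoxyphenyl in place of 3,4-dichlorophenyl on an amine nitrogen in a ring). Among the measured compounds shown here, no measured step covers a methoxy group, so the only guide is that removing chloro reversed the direction seen in a 2.8-fold lower number from compound 1 to compound 2 (0.45 log units; beyond the scatter). Compound 3 is therefore expected to give a higher number, by roughly a 3.4-fold higher number from compound 2 to compound 3 (0.53 log units; beyond the scatter), an estimate of 450 nM with a range of 120 nM to 1800 nM.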

Compound 3, inhibition constant: 921 nM
Beside the measured number, compound 3's estimate is 2.0-fold (0.31 log units) below it; low and high end bracket the measured number.
By their numbers in this assay, from the lowest: compound 2; then compound 1; then compound 3.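

Methoxy does not serve as a replacement for chloro on this aromatic ring: putting methoxy in place of chloro raises the number (a 2.5-fold higher number from compound 1 to compound 3 (0.39 log units; beyond the scatter)). Replacing 3,4-dichlorophenyl with 3-methoxyphenyl raises it further (a 7.0-fold higher number from compound 2 to compound 3 (0.84 log units; beyond the scatter)), so among these three compounds the order runs from the two chloro groups, through the one, to methoxy. No measurement available here explains that order. Still open, from the compounds shown here alone, is how a nitrile or an amine on the ring would compare with chloro. An unsubstituted phenyl on the same ring nitrogen would also show whether methoxy itself raises the number.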